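Notes on compound 4: ethynyl in place of 4-fluorophenyl

The source may report more compounds than this note shows. Statements on the series, on what has been measured and on what is new or still open speak of the compounds shown alone.

Three members of the series have numbers in a functional assay on CHO cells for agonist activity at metabotropic glutamate receptor 5 (Homo sapiens), read by inositol phosphate accumulation; on this read-out lower numbers stand for stronger inhibition and higher numbers for weaker inhibition. Compound 2 `Cc1nc(C#Cc2cncc(-c3ccc(F)cc3)c2)cs1` gives 162 nM in this assay. Compound 3 `COc1ccc(-c2cncc(C#Cc3csc(C)n3)c2)cc1`, which carries methoxy in place of fluoro on an aromatic carbon, gives 225 nM. Compound 1 `Cc1nc(C#Cc2cnc3ccccc3c2)cs1` returns only a limit, > 10000 nM, which marks the edge of this assay rather than a number (the limit of > 10000 nM in this assay, at which 1 of the 3 values shown sits). Among the measured compounds shown here, compound 2 and compound 3 therefore sit within the scatter of each other, the one measured step being a 1.4-fold higher number from compound 2 to compound 3 (0.14 log units; within the scatter).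

Compound 4 `C#Cc1cncc(C#Cc2csc(C)n2)c1` is not yet measured. It differs from compound 2 by ethynyl in place of 4-fluorophenyl on an aromatic carbon. For the measured compounds named here, no measured step removes the whole six-membered ring: the only step in hand, from compound 2 to compound 3, exchanges one substituent on that ring for another and lies within the scatter, so it gives no direct guide. Of compound 1 and compound 2 only the two values can be set side by side, a limit and a number.

With the 4-fluorophenyl gone and only ethynyl remaining, a weaker result is expected, and the step from compound 2 to compound 4 is estimated at a 12-fold higher number from compound 2 to compound 4 (1.09 log units; beyond the scatter). Compound 4 is therefore expected to give about 2000 nM in this assay, between 400 nM and 10000 nM.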

Compound 4, half-maximal inhibitory concentration: 19.2 nM
The estimate for compound 4 lay 100-fold (2.02 log units) above the measured number, and the stated range ends above it.
By their numbers in this assay, from the lowest: compound 4; then compounds 2 and 3 (each within the scatter of the next). At a limit, above all of these: compound 1.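

Ethynyl in place of 4-fluorophenyl gives an 8.4-fold lower number from compound 2 to compound 4 (0.93 log units; beyond the scatter) in this assay, so a low number at this position does not require the six-membered aromatic ring of carbon only. Among the compounds shown here, the earlier step at this position exchanged one substituent on that ring for another and lay within the scatter, whereas this change removes the whole ring, leaves a much smaller group with a triple bond on the aromatic carbon, and gives the first step at this position that lies beyond the scatter. Nothing measured in the series accounts for the size or direction of this step.

As far as these compounds go, it remains open whether the triple bond itself matters or whether any small group on this aromatic carbon would give a similar number, a question that a methyl, a nitrile or a plain hydrogen at the same place would help to settle. Also open, from the compounds shown here alone, is how much size this position tolerates between ethynyl and 4-fluorophenyl, for example with a propynyl group, a longer chain or a terminal amine.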